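This account rests on a few compounds, and the source may have more. Where it says the series, first, only, none or still open, it means among the compounds named here.

In a toxicity assay on L3.6pl cells (Homo sapiens) for inhibition, read by ATP content, with a stated time of 72 h (a higher number here means a weaker inhibitor, a lower number a stronger inhibitor), compound 1 `COc1ccccc1C(=O)Nc1ccc(N2CCN(c3cccc(C)c3C)CC2)cc1C(=O)O` gives 22900 nM. Compound 2 `COc1ccccc1C(=O)Nc1ccc(N2CCN(Cc3ccccc3)CC2)cc1C(=O)O` stands at > 10000 nM, which is a limit of the assay and not a number. Compound 3 `COc1ccccc1C(=O)Nc1ccc(N2CCN(Cc3ccccn3)CC2)cc1C(=O)O` carries pyridin-2-yl in place of phenyl on a saturated chain carbon bound to an amine nitrogen in a ring. For the measured compounds named here, the only measured step is a step that the limit leaves unreadable from compound 1 to compound 2, which concerns a different change and offers no size to carry over. The step expected in this assay is a step that the limit leaves unreadable from compound 2 to compound 3, with no direction expected beyond the scatter. Compound 3 is estimated at 18000 nM, with an expected range of 8000 nM to 40000 nM.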

Compound 3, half-maximal inhibitory concentration: > 100000 nM
Compound 3: a limit, no number (the forecaster's own chance of this, stated with the estimate: 50%); middle value at least 5.5-fold (0.74 log units) from the limit.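

In this assay, for the compounds shown here, the change from 2,3-dimethylphenyl to (pyridin-2-yl)methyl gives an at least 4.3-fold higher number from compound 1 to compound 3 (0.64 log units; beyond the scatter), the only readable step at this position. Compound 3 gives no number, only a limit of the assay: the limit of > 100000 nM in this assay, at which 1 of the 3 values shown sits.

The steps from compound 1 to compound 2 and from compound 2 to compound 3 cannot be read, so pyridin-2-yl in place of phenyl has no size of its own. Left open is how pyridin-3-yl or pyridin-4-yl on the saturated chain carbon, or a longer chain on the amine nitrogen in a ring, would read in this assay.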